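Benzylthio coumarins: methyl for trifluoromethyl on the benzyl ring

A few compounds are considered here, and "the series" means these few. Any claim that something is new, unique, unknown or untested is made for them only; others in the source may bear on it.

Measured so far in a functional assay on A549 cells (Homo sapiens) for antiproliferative activity, read by sulforhodamine B assay, with a stated time of 72 h; on this read-out lower numbers stand for stronger inhibition of growth and higher numbers for weaker inhibition of growth:
compound 1 `Cc1cc(=O)oc2cc(Sc3cccc(Cl)n3)ccc12` gives 2110 nM.
compound 2 `Cc1cc(=O)oc2cc(SCc3cccc(C(F)(F)F)c3)ccc12` gives only a limit, > 28500 nM.

Compound 2 thus sits at the limit of > 28500 nM in this assay, at which 1 of the 2 values shown sits, with no number obtained, and is the weaker of the two results shown. Compound 3 `Cc1cccc(CSc2ccc3c(C)cc(=O)oc3c2)c1` differs from compound 2 by methyl in place of trifluoromethyl on an aromatic carbon. Going by the values given here, no measured pair isolates this change, so in this assay the step is expected to be small, with no direction beyond the scatter. Compound 3 is expected near 25000 nM, between 7000 nM and 90000 nM. The expected step is an at least 1.1-fold lower number from compound 2 to compound 3 (0.05 log units; that floor lies within the scatter), and a further limit rather than a number is likely.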

Compound 3, concentration for 50% growth inhibition: > 33700 nM
Compound 3 gave a limit, no number (the forecaster's own chance of this, stated with the estimate: 60%); middle value at least 1.3-fold (0.12 log units) from the limit.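

Compound 2 and compound 3 each give only a limit, so the step between them cannot be read. The compounds shown leave open whether methyl and trifluoromethyl at this aromatic carbon differ at all in growth inhibition.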